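Naphthalenyl Acid Analog of a Weak Cell-Growth Inhibitor

The compounds below may be only part of what the source reports. "The series", "measured", "known", "first", "only" and "open" are said of these compounds alone.

Measured compounds:
compound 1, `CCOC(=O)C1=Cc2ccccc2OC1(OCc1cc(-c2ccc3ccccc3c2)no1)C(F)(F)F`: 65400 nM
compound 2, `O=C(O)C1=Cc2ccccc2OC1(OCc1cc(-c2ccc([N+](=O)[O-])cc2)no1)C(F)(F)F`: > 150000 nM

Of the compounds shown here, two have been measured in a functional assay on MCF7 cells (Homo sapiens) for inhibition, read by MTT assay, with a stated time of 24 h; on this read-out higher numbers stand for weaker inhibition and lower numbers for stronger inhibition. Compound 1 `CCOC(=O)C1=Cc2ccccc2OC1(OCc1cc(-c2ccc3ccccc3c2)no1)C(F)(F)F` gives 65400 nM in this assay. Compound 2 `O=C(O)C1=Cc2ccccc2OC1(OCc1cc(-c2ccc([N+](=O)[O-])cc2)no1)C(F)(F)F` reaches only the limit of this assay, > 150000 nM, so for compound 2 a boundary rather than a number is known (the limit of > 150000 nM in this assay, at which 1 of the 2 values shown sits).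

Compound 3 `O=C(O)C1=Cc2ccccc2OC1(OCc1cc(-c2ccc3ccccc3c2)no1)C(F)(F)F` differs from compound 2 in one place: naphthalen-2-yl in place of 4-nitrophenyl on an aromatic carbon. Among the compounds with values here, because compound 2 sits at the limit, no measured pair tells how large this step is. Compound 1 carries the same naphthalen-2-yl group and does give a number, 65400 nM, which is the only hint available.

Compound 3 is expected to give 120000 nM in this assay, within a range from 40000 nM to 300000 nM. The step from compound 2 to compound 3 is estimated at an at least 1.2-fold lower number from compound 2 to compound 3 (0.09 log units; that floor lies within the scatter), a modest move toward stronger inhibition, and a result that again only reaches the limit is expected to be quite possible.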

Compound 3, half-maximal inhibitory concentration: > 150000 nM
Compound 3: no number, only a limit (the forecaster's own chance of this, stated with the estimate: 45%); middle value at least 1.2-fold (0.09 log units) away from the limit.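

Within the data shown here, with the naphthalen-2-yl group held constant, compound 1 and compound 3 allow the first comparison of the ethyl ester with the free acid in this assay. Hydrogen in place of ethyl on an oxygen next to a carbonyl group gives an at least 2.2-fold higher number from compound 1 to compound 3 (0.36 log units; beyond the scatter), a change toward weaker inhibition that lies beyond the usual scatter, although its full size stays open since compound 3 reaches only a limit of the assay. The step between compound 2 and compound 3 cannot be read, because both values are limits rather than numbers: the limit of > 150000 nM in this assay, at which 2 of the 3 values shown sit.

Going by these compounds, it remains open whether any aryl group at this place would bring the free acid to a measurable value in this assay. A methyl ester or a primary amide in place of the ethyl ester could show how much of the value of compound 1 depends on the ethyl group.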